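Pyrimidinylamino for Methoxy: a Step Expected Within Scatter

The source may hold more compounds than are shown below. What is called first, only, known or untested is meant among the compounds shown, and "the series" means these compounds.

Three measured compounds share one core and differ only in a single substituent on an aromatic carbon. In a functional assay for inhibition of sodium/hydrogen exchanger (Oryctolagus cuniculus) (on this read-out higher numbers stand for weaker inhibition and lower numbers for stronger inhibition), compound 1 `CCCCCc1cc(C)c(C(=O)N=C(N)N)cc1S(C)(=O)=O` gives 27 nM, compound 2 `Cc1cc(Sc2ccc(Cl)cc2)c(S(C)(=O)=O)cc1C(=O)N=C(N)N` gives 19 nM, and compound 3 `COc1cc(C)c(C(=O)N=C(N)N)cc1S(C)(=O)=O` gives 16 nM. Compound 3 shows the smallest of the three numbers, yet its gaps to the others stay within the scatter: a 1.7-fold lower number from compound 1 to compound 3 (0.23 log units; within the scatter) and a 1.2-fold lower number from compound 2 to compound 3 (0.07 log units; within the scatter), as does a 1.4-fold lower number from compound 1 to compound 2 (0.15 log units; within the scatter). Compound 4 `Cc1cc(Nc2ncccn2)c(S(C)(=O)=O)cc1C(=O)N=C(N)N` carries (pyrimidin-2-yl)amino in place of methoxy on an aromatic carbon. Since every measured step at this position fell within the scatter, the change to compound 4 is expected to be no change at the digits printed from compound 3 to compound 4 (within the scatter), that is no step beyond the scatter in this assay. Compound 4 is therefore estimated at 16 nM, with a range from 5 nM to 50 nM.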

Compound 4, half-maximal inhibitory concentration: 8.3 nM
For compound 4 the middle estimate is 1.9-fold (0.29 log units) above the measured one; the range from low to high includes it.
By their numbers in this assay, from the lowest: compounds 4, 3, 2 and 1 (each within the scatter of the next, the first and the last beyond it).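

In this assay, going by these compounds alone, the position ortho to a methylsulfonyl group accepts (pyrimidin-2-yl)amino, the only group here with a hetero-atom ring and a hydrogen-bond donor, and a 1.9-fold lower number from compound 3 to compound 4 (0.29 log units; within the scatter) stays within the scatter. Within the data shown here, this change also gives the first steps at this position beyond the scatter, both modest: a 2.3-fold lower number from compound 2 to compound 4 (0.36 log units; beyond the scatter) and a 3.3-fold lower number from compound 1 to compound 4 (0.51 log units; beyond the scatter) are the two. Nothing available explains these steps.

On these data alone, whether a phenylamino group, a plain amine or a carboxylic acid at this position would give similar numbers remains open.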